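The source may report more compounds than this note shows. Statements on the series, on what has been measured and on what is new or still open speak of the compounds shown alone.

In a functional assay on HeLa cells (Homo sapiens) for cytotoxicity, read by MTT assay, with a stated time of 24 h (a higher number here means a weaker inhibitor, a lower number a stronger inhibitor), compound 3 `C=CC1=C(C(=O)NCCCCC)C(c2ccc(F)cc2)OC1` gives only a limit, > 100000 nM. Compound 1 `C=CC1=C(C(=O)NCCCCC)C(c2ccc(OC)cc2)OC1` likewise stops at a limit, > 100000 nM. Compound 2 `C=CC1=C(C(=O)Nc2ccccc2OC)C(c2ccc(F)cc2)OC1` also returns only a limit, > 100000 nM. Both recorded steps, a step that the two limits leave unreadable from compound 1 to compound 3 and a step that the two limits leave unreadable from compound 2 to compound 3, are consequently unreadable in size and direction, since every value sits at the limit of > 100000 nM in this assay, at which 3 of the 3 values shown sit. Compound 4 `C=CC1=C(C(=O)NC(C)(C)C)C(c2ccc(F)cc2)OC1` differs from compound 3 by tert-butyl in place of pentyl on an amide-type nitrogen. Among the compounds with values here, no measured step touches the amide-type nitrogen in a readable way, so nothing argues for a shift beyond the scatter. The step that the limit leaves unreadable from compound 3 to compound 4 is expected to be flat. Compound 4 is expected to give 150000 nM, within 50000 nM to 500000 nM, most probably again reported only as a limit.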

Compound 4, half-maximal inhibitory concentration: > 100000 nM
Compound 4 gave a limit, no number; the forecaster's own chance of this, stated with the estimate: 85%; the middle value is on the limit's open side.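

Within the data shown here, no step to compound 4, from compound 3 or from compound 2, can be read in this assay, because all the values are limits: the limit of > 100000 nM in this assay, at which 4 of the 4 values shown sit. The compounds shown leave open whether pentyl, tert-butyl and 2-methoxyphenyl on the amide-type nitrogen differ at all in cytotoxicity.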